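Swapping Hydrogen for Chloro on an Aromatic Carbon

The source may report more compounds than this note shows. Statements on the series, on what has been measured and on what is new or still open speak of the compounds shown alone.

Compound 1 `C(=C1\CCN=C1c1cccnc1)\c1ccccc1` gives 41.3% in an assay for displacement of a labelled ligand from Nicotinic acetylcholine receptor alpha8 subunit (Periplaneta americana), read by scintillation counting, with a stated time of 2 h, at 24 degrees C, tested at 10 uM; a lower number here means less inhibition, a higher number more inhibition at the concentration tested (going by the name of the read-out).
Compound 2 `Oc1cccc(/C=C2\CCN=C2c2cccnc2)c1` gives 32.1% in this assay.
Compound 3 `COc1cccc(/C=C2\CCN=C2c2cccnc2)c1` gives 23.6% in this assay.

Compound 1 has the highest of the three numbers, though its gap to compound 2 is within the scatter; only compound 3 sits clearly lower. The unmeasured compound 4 `Clc1ccc(/C=C2\CCN=C2c2cccnc2)cc1` differs from compound 1 in one place: chloro in place of hydrogen on an aromatic carbon.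

Among the measured compounds shown here, two measured steps bear on this change, since each also puts a new group on an aromatic carbon of compound 1. Adding hydroxy gave a number 9.2 percentage points lower from compound 1 to compound 2 (within the scatter), and adding methoxy gave a number 17.7 percentage points lower from compound 1 to compound 3 (beyond the scatter). Both went downward, one within and one beyond the scatter. Chloro is a different group from either, so the guidance is loose, but nothing in the measured steps suggests a rise.

Compound 4 is therefore expected to land somewhat below compound 1, a shift of about a number 7.3 percentage points lower from compound 1 to compound 4 (within the scatter) that may still fall within the scatter. The estimate for compound 4 in this assay is 34%, with a range from 20% to 50%.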

Compound 4, a percentage reported as inhibition, at one concentration (the size of the read-out at that concentration, not a potency): 21.5%
Compound 4: middle estimate off by 12.5 percentage points, on the high side; the range from low to high includes it.
By their numbers in this assay, from the lowest: compounds 4, 3, 2 and 1 (each within the scatter of the next, the first and the last beyond it).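

Chloro, a single atom with no hydrogen-bond donors or acceptors, still gives a number a number 19.8 percentage points lower from compound 1 to compound 4 (beyond the scatter), so a clear step down does not require a group containing oxygen. With this result, all three groups shown on the aromatic ring of compound 1 give lower numbers, although the hydroxy step in compound 2 stays within the scatter and so does not firmly support that trend. Nothing available explains why chloro in this place lowers the inhibition.

The compounds shown leave open whether fluoro or bromo in this same place would behave like chloro, and how an amine or a carboxylic acid would read there. They also leave open what chloro would do on a different carbon of this ring.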